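A few compounds are considered here, and "the series" means these few. Any claim that something is new, unique, unknown or untested is made for them only; others in the source may bear on it.

Measured in a functional assay on K562 cells (Homo sapiens) for cytotoxicity, read by sulforhodamine B assay, with a stated time of 48 h; a lower number here means a stronger inhibitor, a higher number a weaker inhibitor:

- compound 1 `CCN(CC)CCCn1c(=O)/c(=C/c2cc(OC)c(OC)c(OC)c2)s/c1=C1/C(=O)Nc2ccc(C)cc21`: 4170 nM
- compound 2 `CCN(CC)CCCn1c(=O)/c(=C/c2ccc(O)cc2)s/c1=C1\C(=O)Nc2ccc(Cl)cc21`: 24600 nM
- compound 3 `CCN(CC)CCCn1c(=O)/c(=C/c2ccc(O)cc2)s/c1=C1/C(=O)Nc2ccc(Cl)cc21`: 24600 nM

Compound 2 stands level with compound 3, and the two share the highest number of the three, while compound 1 lies clearly lower at 4170 nM. The next compound to be tested is compound 4 `CCN(CC)CCCn1c(=O)/c(=C/c2cc(OC)c(OC)c(OC)c2)s/c1=C1\C(=O)Nc2ccc(Cl)cc21`, which differs from compound 2 at one place: 3,4,5-trimethoxyphenyl in place of 4-hydroxyphenyl on a double-bonded chain carbon bound to an aromatic carbon. The group is exchanged on a double-bonded chain carbon bound to an aromatic carbon.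

Within the data shown here, the only measured step is no change at the digits printed from compound 2 to compound 3 (within the scatter). It concerns the fact that compounds 2 and 3 differ only in the configuration as drawn and does not touch the aromatic group, so it gives no direct size for this exchange. It does suggest that the drawn configuration of that double bond need not weigh much in this assay.

The closest guide is compound 1, which carries the same 3,4,5-trimethoxyphenyl and gives 4170 nM on a core that is not identical to that of compound 2. Among the measured compounds shown here, no measured step isolates that core difference, so the range stays wide.

The expected change, a 3.5-fold lower number from compound 2 to compound 4 (0.55 log units; beyond the scatter), is toward a lower number and probably beyond the scatter. The estimate for compound 4 is 7000 nM, with an expected range of 2500 nM to 20000 nM.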

Compound 4, half-maximal inhibitory concentration: 820 nM
Compound 4: middle estimate off by 8.5-fold (0.93 log units), on the high side, and the stated range ends above it.
By their numbers in this assay, from the lowest: compound 4; then compound 1; then compounds 2 and 3 (each within the scatter of the next).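

In this assay, exchanging 4-hydroxyphenyl for 3,4,5-trimethoxyphenyl on a double-bonded chain carbon bound to an aromatic carbon gives a 30-fold lower number from compound 2 to compound 4 (1.48 log units; beyond the scatter), the first measured size for a change at this position. The earlier compounds offered only a change of drawn configuration, no change at the digits printed from compound 2 to compound 3 (within the scatter), so this aromatic group is the first part of the structure shown to move the number in this series. The exchange changes several counted features at once, among them the heavy atoms, the hydrogen-bond donors and the hydrogen-bond acceptors, and nothing at hand says which of these carries the step or why it is so large.

Still open, on these data alone, is whether the hydroxyl loss or the methoxy gain matters more, a question that 4-methoxyphenyl or 3,5-dimethoxyphenyl on the core of compound 2 would help to separate. Also open, as far as these compounds go, is whether the step holds with the other drawn configuration of the double bond, and whether an amine such as morpholine can stand in for the diethylamino end of the chain.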